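Replacing trifluoromethyl with methyl in compound 2

A few compounds are considered here, and "the series" means these few. Any claim that something is new, unique, unknown or untested is made for them only; others in the source may bear on it.

In a functional assay on PC-3 cells (Homo sapiens) for cytotoxicity, read by MTT assay, with a stated time of 72 h (a lower number here means a stronger inhibitor, a higher number a weaker inhibitor), compound 2 `CNC(=O)c1cc(Oc2ccc(NC(=O)c3cc(-c4ccc(C(F)(F)F)cc4)ncn3)cc2F)ccn1` stands at a limit of the assay, > 100000 nM. Compound 4 `CNC(=O)c1cc(Oc2ccc(NC(=O)c3cc(-c4ccc(C)cc4)ncn3)cc2F)ccn1` differs from it in one place: methyl in place of trifluoromethyl on an aromatic carbon. Among the compounds with values here, no measured step makes this exact change. The nearest evidence comes from a different core, where compound 1 `CNC(=O)c1cc(Oc2ccc(NC(=O)c3nccc(-c4ccccc4)n3)cc2)ccn1` gives 7310 nM. Compound 3 `CNC(=O)c1cc(Oc2ccc(NC(=O)c3nccc(-c4ccc([N+](=O)[O-])cc4)n3)cc2)ccn1` also stands at a limit, > 100000 nM. The nitro in place of hydrogen there is a large step, an at least 13-fold higher number from compound 1 to compound 3 (1.13 log units; beyond the scatter), and that step is bounded by the limit of > 100000 nM in this assay, at which 2 of the 3 values shown sit. On that step alone, a moderate move to a lower number is expected, an at least 3.3-fold lower number from compound 2 to compound 4 (0.52 log units; beyond the scatter), although compound 4 may remain at the limit. For compound 4 the estimated value is 30000 nM, with an expected range of 6000 nM to 100000 nM.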

Compound 4, half-maximal inhibitory concentration: 40200 nM
Compound 4: the middle estimate sits 1.3-fold (0.13 log units) below what was measured; low and high end bracket the measured number.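

In this assay, methyl in place of trifluoromethyl gives an at least 2.4-fold lower number from compound 2 to compound 4 (0.39 log units; beyond the scatter), so on this core the group para to a large group can bring the read-out off the limit. The earlier step, on the core of compound 1, showed only a move up to a limit, with nitro in place of hydrogen. Compound 2 stands at a limit, so this step gives only a bound on the size of the change: the limit of > 100000 nM in this assay, at which 2 of the 4 values shown sit.

On these data alone, what an amine, a methoxy group or a longer chain such as ethyl would give at this place on the core of compound 2 remains open.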